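Toxicity of side-chain amine variants: dimethylamino to methylpiperazine

The source may report more compounds than this note shows. Statements on the series, on what has been measured and on what is new or still open speak of the compounds shown alone.

Working notes on the series, toxicity read-out. In a toxicity assay on cells (Macrophage, Homo sapiens) for inhibition, read by MTT assay (a higher number here means a weaker inhibitor, a lower number a stronger inhibitor), compound 2 (`CN(C)CCCNc1nc(-c2ccc(F)cc2)nc2ccccc12`) gives 63000 nM. Going by the values given here, this is the only number available so far, so it cannot be ranked against anything. The entry for compound 1 (`CN1CCN(CCCNc2nc(-c3ccc(Cl)cc3)nc3ccccc23)CC1`) reads "nd" (no result reported), and that compound offers no comparison.

The next compound to be measured is compound 3 (`CN1CCN(CCCNc2nc(-c3ccc(F)cc3)nc3ccccc23)CC1`). It carries 4-methylpiperazin-1-yl in place of dimethylamino on a saturated chain carbon, three bonds along the chain from a nitrogen on an aromatic ring.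

Among the compounds with values here, no measured pair shows this change, so the data give no direct guide to its size or direction. The expectation therefore rests on compound 2 at 63000 nM alone, and no shift beyond the scatter is expected in this assay. The estimated change is a 1.1-fold lower number from compound 2 to compound 3 (0.02 log units; within the scatter), with its direction left open. Compound 3 is expected at about 60000 nM, with an estimated range of 25000 nM to 150000 nM.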

Compound 3, half-maximal inhibitory concentration: 40000 nM
Compound 3: middle estimate off by 1.5-fold (0.18 log units), on the high side; low and high end bracket the measured number.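

In this assay, going by these compounds alone, 4-methylpiperazin-1-yl in place of dimethylamino on a saturated chain carbon, three bonds along the chain from a nitrogen on an aromatic ring, gives a 1.6-fold lower number from compound 2 to compound 3 (0.20 log units; within the scatter) as the first readable step. At this position, then, an open dimethylamino group and a six-membered non-aromatic ring with 2 hetero atoms cannot be told apart by this read-out, even though the entering group is the larger one and carries the second nitrogen. No measured property in hand bears on this result, and the pair offers no account of why the two compounds read as they do.

The compounds shown leave open whether other groups at the same place, such as morpholin-4-yl with a ring oxygen in place of the methylated nitrogen, or a primary amine, would stay within the scatter of compound 2 and compound 3 or move clearly away from them. They also leave open whether a longer chain carrying the 4-methylpiperazin-1-yl group would give a reading that differs from that of compound 3 on the shared core.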